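Replacing 3-nitrophenyl with thiophen-2-yl: an expected step

The source may report more compounds than this note shows. Statements on the series, on what has been measured and on what is new or still open speak of the compounds shown alone.

Values from a functional assay on HCT-116 cells (Homo sapiens) for antiproliferative activity, read by MTT assay, with a stated time of 24 h (a higher number here means a weaker inhibitor, a lower number a stronger inhibitor), for the measured compounds:
- Compound 1 `COc1ccc(C(=O)/C=C/c2ccc3ccccc3c2)c2c1C=CC(C)(C)O2` gives 5820 nM
- Compound 2 `COc1ccc(C(=O)/C=C/c2cccc([N+](=O)[O-])c2)c2c1C=CC(C)(C)O2` gives 8050 nM
- Compound 3 `COc1ccc(C(=O)/C=C/c2cccc(C(F)(F)F)c2)c2c1C=CC(C)(C)O2` gives 9710 nM

Compound 2 lies within the scatter of both compound 1 and compound 3, so it cannot be set apart from either. Compound 4 `COc1ccc(C(=O)/C=C/c2cccs2)c2c1C=CC(C)(C)O2` has not yet been measured. It carries thiophen-2-yl in place of 3-nitrophenyl on a double-bonded chain carbon bound to a double-bonded chain carbon. Going by the values given here, one measured step bears on this (a 1.2-fold higher number from compound 2 to compound 3 (0.08 log units; within the scatter)), but it exchanges trifluoromethyl and nitro on an aromatic carbon and leaves the ring in place. Among the compounds with values here, no measured compound has a five-membered aromatic ring, so the support is indirect. On this evidence, no step beyond the scatter is expected in this assay for this change. The estimated step is small (a 1.1-fold lower number from compound 2 to compound 4 (0.03 log units; within the scatter)). Compound 4 is expected at 7500 nM (estimated range 3500 nM to 15000 nM).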

Compound 4, half-maximal inhibitory concentration: > 10000 nM
Compound 4 was reported as a limit; the forecaster's own chance of this, stated with the estimate: 3%; at least 1.3-fold (0.12 log units) between middle value and limit.
By their numbers in this assay, from the lowest: compounds 1, 2 and 3 (each within the scatter of the next). At a limit, above all of these: compound 4.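

In this assay compound 4 gives > 10000 nM, which is a limit of the assay and not a number. Among the changes shown, this is the one that exchanges the whole ring on the double-bonded chain carbon rather than a group on that ring, and it reads as an at least 1.2-fold higher number from compound 2 to compound 4 (0.09 log units; that floor lies within the scatter), so the floor does not set the two compounds apart and the true size of the step remains unknown. Compound 4 is the only compound shown that reaches this limit: the limit of > 10000 nM in this assay, at which 1 of the 4 values shown sits.

Going by these compounds, it stays open whether the limit goes with the five-membered ring or with its sulfur. Also open, on these data alone, is how furan-2-yl, or a phenyl ring carrying an amine or a carboxylic acid, would read at this place in this assay.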